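This account rests on a few compounds, and the source may have more. Where it says the series, first, only, none or still open, it means among the compounds named here.

In an ADME assay on Caco-2 cells (Homo sapiens) for permeability, read by LC-MS, in the apical to basolateral direction, with a stated time of 60 min, at pH 6.5 (a higher number here means that the compound crosses the layer faster, a lower number that the compound crosses the layer more slowly), compound 1 `CC(C)(C)[C@@H](O)C(=O)N1C[C@@H]2C[C@@H]2[C@H]1C(=O)NCc1cc(Cl)ccc1-n1cnnn1` gives 17 10^-6 cm/s. Compound 2 `CC(C)(C)C[C@@H](O)C(=O)N1N=CC[C@H]1C(=O)NCc1cc(Cl)ccc1-n1cnnn1` gives 24 10^-6 cm/s in this assay; the difference between the two cores of compound 1 and compound 2 is not broken down here. Compound 3 `O=C(NCc1cc(Cl)ccc1-n1cnnn1)[C@@H]1CC=NN1C(=O)[C@H](O)Cc1ccccc1` carries phenyl in place of tert-butyl on a saturated chain carbon, two bonds along the chain from a carbonyl carbon and an oxygen on a saturated carbon and gives 11 10^-6 cm/s in this assay, a step of a 2.2-fold lower number from compound 2 to compound 3 (0.34 log units; beyond the scatter). Compound 4 `O=C(NCc1cc(Cl)ccc1-n1cnnn1)[C@@H]1[C@H]2C[C@H]2CN1C(=O)[C@H](O)c1ccccc1` stands to compound 1 through (phenyl in place of tert-butyl on a saturated chain carbon bound to a carbonyl carbon and an oxygen on a saturated carbon). This is the same kind of change, but in compound 4 the saturated chain carbon is bound to a carbonyl carbon and an oxygen on a saturated carbon, whereas in compound 3 it lies two bonds along the chain from a carbonyl carbon and an oxygen on a saturated carbon. Resting on the earlier step of a 2.2-fold lower number from compound 2 to compound 3 (0.34 log units; beyond the scatter), compound 4 is expected to show a step of a 1.9-fold lower number from compound 1 to compound 4 (0.28 log units; within the scatter) in this assay. The estimate for compound 4 is 9 10^-6 cm/s, expected between 5 10^-6 cm/s and 16 10^-6 cm/s.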

Compound 4, apparent permeability: 12 10^-6 cm/s
Compound 4: middle estimate off by 1.3-fold (0.12 log units), on the low side, within the range that was stated.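

In this assay, phenyl in place of tert-butyl on a saturated chain carbon bound to a carbonyl carbon and an oxygen on a saturated carbon gives a 1.4-fold lower number from compound 1 to compound 4 (0.15 log units; within the scatter). Set beside the earlier step, the change carries from one core to the other with no difference that can be told apart: the same change on two cores in this assay, a 2.2-fold lower number (0.34 log units; beyond the scatter) from compound 2 to compound 3 and a 1.4-fold lower number (0.15 log units; within the scatter) from compound 1 to compound 4, 1.5-fold (0.19 log units) apart, within the scatter of two such steps This rests on only two pairs, and the change sits at a different place along the chain in each, so it does not show that the step has a fixed size or that it would hold on a further core.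

The compounds shown leave open how an amine or a carboxylic acid at this place would read in this assay. They also leave open whether a longer chain ending in phenyl or tert-butyl would follow the same step on either core.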